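A Chain in Place of a Ring on the Amine Nitrogen

The source may report more compounds than this note shows. Statements on the series, on what has been measured and on what is new or still open speak of the compounds shown alone.

Of the compounds shown here, three have been measured in an assay on CHO cells for displacement of a labelled ligand from Substance-P receptor (Homo sapiens), read by scintillation counting; on this read-out lower numbers stand for stronger inhibition and higher numbers for weaker inhibition: compound 1 `Cc1cc(F)ccc1[C@H]1C[C@@H](N2CCC2)CCN1C(=O)N(C)[C@H](C)c1cc(C(F)(F)F)cc(C(F)(F)F)c1` gives 0.178 nM, compound 2 `Cc1cc(F)ccc1[C@H]1C[C@@H](N2CCCC2)CCN1C(=O)N(C)[C@H](C)c1cc(C(F)(F)F)cc(C(F)(F)F)c1` gives 0.141 nM, and compound 3 `Cc1cc(F)ccc1[C@H]1C[C@@H](NC2CC2)CCN1C(=O)N(C)[C@H](C)c1cc(C(F)(F)F)cc(C(F)(F)F)c1` gives 0.324 nM.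

Compound 3 stands at the highest number of the three. One of its gaps is a 1.8-fold higher number from compound 1 to compound 3 (0.26 log units; within the scatter), which lies within the scatter, while the other is a 2.3-fold higher number from compound 2 to compound 3 (0.36 log units; beyond the scatter), a modest step beyond it. The two ring amines differ from each other by a 1.3-fold lower number from compound 1 to compound 2 (0.10 log units; within the scatter), within the scatter.

Compound 4 `COCCN[C@H]1CCN(C(=O)N(C)[C@H](C)c2cc(C(F)(F)F)cc(C(F)(F)F)c2)[C@@H](c2ccc(F)cc2C)C1` differs from compound 3 in one place: 2-methoxyethyl in place of cyclopropyl on an amine nitrogen. Among the measured compounds shown here, no measured step swaps a ring on this nitrogen for an open chain, so the measured steps bear on it only loosely. All three changes at the same amine nitrogen left the number in a narrow band, the largest of them being a 2.3-fold higher number from compound 2 to compound 3 (0.36 log units; beyond the scatter). A step of similar size or smaller is therefore expected in this assay, with no firm direction. For compound 4 the expected number in this assay is 0.35 nM, with a range from 0.12 nM to 1 nM, which corresponds to an expected step of a 1.1-fold higher number from compound 3 to compound 4 (0.03 log units; within the scatter).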

Compound 4, inhibition constant: 0.209 nM
Estimate against measurement, compound 4: 1.7-fold (0.22 log units) above, and the stated range covers the measured number.
By their numbers in this assay, from the lowest: compounds 2, 1, 4 and 3 (each within the scatter of the next, the first and the last beyond it).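

In this assay, an open chain carrying an ether oxygen takes the place of a small carbon ring on the amine nitrogen, and the step is a 1.6-fold lower number from compound 3 to compound 4 (0.19 log units; within the scatter) so the two compounds cannot be told apart. Among the compounds shown here, this is the first sign that a ring on this nitrogen is not required to keep the number in the sub-nanomolar band seen so far. The same holds against the two ring amines, with a 1.5-fold higher number from compound 2 to compound 4 (0.17 log units; within the scatter) and a 1.2-fold higher number from compound 1 to compound 4 (0.07 log units; within the scatter) so compound 4 sits within the scatter of all three earlier compounds, even though compound 2 and compound 3 lie just beyond the scatter of each other, and nothing available explains why the number holds so steady through this change.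

Going by these compounds, a plain butyl chain on the same nitrogen would separate the effect of losing the ring from the effect of adding the oxygen, and that question stays open here. Also open, on these data alone, is whether a much larger end to the chain, such as a phenyl ring or a carboxylic acid, would keep the number in this narrow band.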